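A few compounds are considered here, and "the series" means these few. Any claim that something is new, unique, unknown or untested is made for them only; others in the source may bear on it.

Measured compounds:
- compound 1, `Cc1nc(-c2ccc(C(F)(F)F)cc2)sc1COc1ccc(OCC(=O)O)c(F)c1`: 149 nM
- compound 2, `Cc1nc(-c2ccc(F)cc2)sc1COc1ccc(OCC(=O)O)c(F)c1`: 112 nM
- compound 3, `Cc1nc(-c2ccc(F)cc2)sc1COc1ccc(CCC(=O)O)cc1`: 251 nM

Of the compounds shown here, three have been measured in an assay on CHO cells for agonist activity at Free fatty acid receptor 1 (Homo sapiens), read by FLIPR (a lower number here means that less compound is needed, a higher number that more compound is needed for the effect), and a fourth, compound 4, `Cc1nc(-c2ccc(C(F)(F)F)cc2)sc1COc1ccc(CCC(=O)O)cc1`, is still waiting for its number.

Compounds 1 and 2 share one core and differ in a single place: trifluoromethyl in place of fluoro on an aromatic carbon. That change gave a 1.3-fold higher number from compound 2 to compound 1 (0.12 log units; within the scatter). The two values thus sit close together.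

Compound 3 has a different core; how its core differs from that of compound 2 is not broken down here. In this assay compound 3 gives 251 nM, the highest of the three numbers, though its gap to compound 1 lies within the scatter.

Compound 4 is built from compound 3 by the same change that leads from compound 2 to compound 1: trifluoromethyl in place of fluoro on an aromatic carbon. The place is described in the same words for both pairs, so this is the same change on a different core.

Because the step of a 1.3-fold higher number from compound 2 to compound 1 (0.12 log units; within the scatter) was small, compound 4 is expected to land near compound 3, with an estimated step of a 1.3-fold higher number from compound 3 to compound 4 (0.12 log units; within the scatter). This rests on a single earlier example, so the expectation is loose. The estimate for compound 4 is 330 nM, with a likely range from 150 nM to 720 nM.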

Compound 4, half-maximal effective concentration: 325 nM
Compound 4: the middle estimate sits 1.0-fold (0.01 log units) above what was measured, and the stated range covers the measured number.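

In this assay, putting trifluoromethyl in place of fluoro on the core of compound 3 gave a 1.3-fold higher number from compound 3 to compound 4 (0.11 log units; within the scatter). Set beside the same change on the core of compound 1, this second step has the same size: the same change on two cores in this assay, a 1.3-fold higher number (0.12 log units; within the scatter) from compound 2 to compound 1 and a 1.3-fold higher number (0.11 log units; within the scatter) from compound 3 to compound 4, 1.0-fold (0.01 log units) apart, within the scatter of two such steps

So, in this series, the change carried from one core to the other without its size shifting, and on both cores it left the number within what repeated measurements would scatter; it does not show a real direction for the change, does not explain why the steps match, and, resting on only two pairs, says nothing about cores beyond these two.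

The compounds shown leave open whether a different group at the same place on the aromatic ring, such as a nitrile or an amine, would give a step beyond the scatter, and whether that step would also stay the same from one core to the other. They also leave open whether the trifluoromethyl and fluoro pair would behave alike on a core that carries an amide in place of the carboxylic acid, or a longer chain leading to that acid.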